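Phenyl in Place of the Ester on the Anilide Ring

The source may hold more compounds than are shown below. What is called first, only, known or untested is meant among the compounds shown, and "the series" means these compounds.

Compound 3 `CCOC(=O)c1ccc(NC(=O)CSc2nc3c(c(=O)n2-c2ccccc2)SCC3)cc1` gives 300 nM in an assay on L cells for inhibition of Protein-serine O-palmitoleoyltransferase porcupine (Mus musculus), read by reporter gene assay, with a stated time of 24 h (a higher number here means that more compound is needed for the effect, a lower number that less compound is needed), the highest of the two numbers shown. Its nearest neighbour is compound 1 `O=C(CSc1nc2c(c(=O)n1-c1ccccc1)SCC2)Nc1ccc(-c2ccncc2)cc1`, which gives 3 nM; the rise a 100-fold higher number from compound 1 to compound 3 (2.00 log units; beyond the scatter) was large. Compound 2 `CC(=O)c1ccc(NC(=O)CSc2nc3c(c(=O)n2-c2ccccc2)SCC3)cc1` is reported only as a limit, > 1000 nM (the limit of > 1000 nM in this assay, at which 1 of the 3 values shown sits). The steps of an at least 330-fold higher number from compound 1 to compound 2 (2.52 log units; beyond the scatter) and an at least 3.3-fold lower number from compound 2 to compound 3 (0.52 log units; beyond the scatter) complete the measured picture. Compound 4 `O=C(CSc1nc2c(c(=O)n1-c1ccccc1)SCC2)Nc1ccc(-c2ccccc2)cc1` arises through (phenyl in place of ethoxycarbonyl on an aromatic carbon). The step bearing most on it is the large rise a 100-fold higher number from compound 1 to compound 3 (2.00 log units; beyond the scatter), since the phenyl change removes the ethoxycarbonyl again. A large fall is therefore expected in this assay, with the expected step of a 15-fold lower number from compound 3 to compound 4 (1.18 log units; beyond the scatter). Compound 4 is estimated at 20 nM, within a range from 4 nM to 100 nM.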

Compound 4, half-maximal effective concentration: 0.75 nM
Compound 4: the middle estimate sits 27-fold (1.43 log units) above what was measured; the whole stated range lies above it.
By their numbers in this assay, from the lowest: compound 4; then compound 1; then compound 3. At a limit, above all of these: compound 2.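

In this assay, within the data shown here, a six-membered aromatic ring of carbon only at this place, para to a large group, gives the lowest number so far, and the pyridin-4-yl proves unnecessary for a low number: a 4.0-fold lower number from compound 1 to compound 4 (0.60 log units; beyond the scatter). Both ring-bearing compounds lie far below the two carbonyl-bearing ones, with a 400-fold lower number from compound 3 to compound 4 (2.60 log units; beyond the scatter) and an at least 1300-fold lower number from compound 2 to compound 4 (3.12 log units; beyond the scatter). The last step rests on compound 2, whose value is a limit: the limit of > 1000 nM in this assay, at which 1 of the 4 values shown sits.

From the compounds shown here alone, whether a saturated ring such as piperidine would serve here remains open. So does the effect of an amine or a carboxylic acid on the added phenyl.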